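Growing the Ether Substituent: Expected Permeability of Compound 4

The source may hold more compounds than are shown below. What is called first, only, known or untested is meant among the compounds shown, and "the series" means these compounds.

Of the compounds shown here, three have been measured in a physicochemical assay for permeability, using PAMPA; a higher number here means that the compound crosses the layer faster, a lower number that the compound crosses the layer more slowly.
Compound 1 `CC(C)Cc1cc2oc(=O)n(CCC(=O)O)c2cc1Cl`: < 10 nm/s, a limit of the assay.
Compound 2 `O=C(O)CCn1c(=O)oc2cc(OCC3CC3)c(Cl)cc21`: 19 nm/s.
Compound 3 `COc1cc2oc(=O)n(CCC(=O)O)c2cc1Cl`: < 3 nm/s, a limit of the assay.

Compound 3 therefore has no number of its own, only (the limit of < 3 nm/s in this assay, at which 1 of the 3 values shown sits). Compound 1 likewise sits at a limit, (the limit of < 10 nm/s in this assay, at which 1 of the 3 values shown sits), so only compound 2 gives a measured number.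

Compound 4 `C[C@@H](Oc1cc2oc(=O)n(CCC(=O)O)c2cc1Cl)c1ncco1` differs from compound 3 by a group of 7 heavy atoms (5 carbon, 1 nitrogen, 1 oxygen; one five-membered aromatic ring with 2 hetero atoms) in place of one carbon atom, on an oxygen on an aromatic ring. Among the compounds with values here, the one measured step that touches this oxygen is an at least 6.3-fold lower number from compound 2 to compound 3 (0.80 log units; beyond the scatter), in which the group on the chain carbon bound to that oxygen was cut down. Compound 4 goes the other way and enlarges that group, so the reverse, a rise of at least modest size, is expected: an at least 3.3-fold higher number from compound 3 to compound 4 (0.52 log units; beyond the scatter). Compound 4 is expected to give about 10 nm/s, with a range from 3 nm/s to 30 nm/s.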

Compound 4, apparent permeability: < 3 nm/s
Compound 4: only a limit was reported; the forecaster's own chance of this, stated with the estimate: 35%; middle value at least 3.3-fold (0.52 log units) away from the limit.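

In this assay compound 4 gives only a limit of the assay, < 3 nm/s, and so shares the floor reached by compound 3: the limit of < 3 nm/s in this assay, at which 2 of the 4 values shown sit. Enlarging the group on this oxygen is therefore not enough in itself to give a readable number, and the exchange of the cyclopropyl-bearing group for the new one gives an at least 6.3-fold lower number from compound 2 to compound 4 (0.80 log units; beyond the scatter). The steps to compound 4 from compound 1 and compound 3 cannot be read.

From the compounds shown here alone, whether a longer alkyl chain or a phenyl ring on this oxygen would give a readable number remains open. So does any difference between compound 3 and compound 4 beneath the limit.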